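This account rests on a few compounds, and the source may have more. Where it says the series, first, only, none or still open, it means among the compounds named here.

Working notes on the series. Compound 1 `O=C(/C=C/c1cccc(OCc2ccccc2)c1)c1ccc(O)cc1` bears a hydroxy group on the aryl ketone and in a functional assay on A2780 cells (Homo sapiens) for cytotoxicity, read by MTT assay, with a stated time of 68 h (a higher number here means a weaker inhibitor, a lower number a stronger inhibitor), compound 1 gives 1000 nM, the lowest of the three numbers in hand. Compound 2 `O=C(/C=C/c1cccc(OCc2ccccc2)c1)c1ccc(Cl)cc1` gives 56400 nM, and compound 3 `O=C(/C=C/c1cccc(OCc2ccccc2)c1)c1ccc(Cl)c(Cl)c1Cl` gives 1500 nM. The step of a 56-fold higher number from compound 1 to compound 2 (1.75 log units; beyond the scatter) is large; the step of a 1.5-fold higher number from compound 1 to compound 3 (0.18 log units; within the scatter) stays within the scatter, and the step of a 38-fold lower number from compound 2 to compound 3 (1.58 log units; beyond the scatter) is again large, so the weak number belongs to compound 2 alone.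

Compound 4 `O=C(/C=C/c1cccc(OCc2ccccc2)c1)c1ccccc1` differs from compound 1 by hydrogen in place of hydroxy on an aromatic carbon. For the measured compounds named here, the step that bears on this is the one from compound 1 to compound 2, where the hydroxy was also lost, and it was large in the weaker direction. Compound 3 shows that a ketone aryl without hydroxy need not be weak, so the size is uncertain. For compound 4 a step of an 8.0-fold higher number from compound 1 to compound 4 (0.90 log units; beyond the scatter) toward a higher number is expected in this assay, smaller than that seen for compound 2. Compound 4 is estimated at 8000 nM, within 1500 nM to 40000 nM.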

Compound 4, half-maximal inhibitory concentration: 6700 nM
Estimate against measurement, compound 4: 1.2-fold (0.08 log units) above, and the stated range covers the measured number.
By their numbers in this assay, from the lowest: compounds 1 and 3 (each within the scatter of the next); then compound 4; then compound 2.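

In this assay, the hydroxy change alone gives a 6.7-fold higher number from compound 1 to compound 4 (0.83 log units; beyond the scatter), so the 4-hydroxyphenyl to phenyl change accounts for only part of the large step seen earlier for compound 2. With the phenyl compound as the reference, the single chloro replacement reads as an 8.4-fold lower number from compound 2 to compound 4 (0.93 log units; beyond the scatter), while the trichlorophenyl replacement reads as a 4.5-fold higher number from compound 3 to compound 4 (0.65 log units; beyond the scatter), so chloro substitution on this ring goes with numbers on both sides of compound 4. No measurement in hand accounts for either direction.

From the compounds shown here alone, it remains open how a methoxy group, an amine or a fluoro group would read in place of the hydroxy on this ring. The compounds shown also leave open whether the hydroxy step holds when the benzyloxy group of the shared core is replaced by a shorter ether such as methoxy.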